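A few compounds are considered here, and "the series" means these few. Any claim that something is new, unique, unknown or untested is made for them only; others in the source may bear on it.

Measured so far in a functional assay on MDA-MB-231 cells (Homo sapiens) for inhibition, read by MTT assay, with a stated time of 48 h; a lower number here means a stronger inhibitor, a higher number a weaker inhibitor:
compound 1 `CN1CCN(c2ccc(Nc3ncc4c(n3)N(C3CCCC3)CC(=O)N4)cc2)CC1`: 26100 nM
compound 2 `O=C1CN(C2CCCC2)c2nc(Nc3ccc(N4CCNCC4)cn3)ncc2N1`: a limit only, > 30000 nM
compound 3 `CN1CCN(c2ccc(Nc3ncc4c(n3)N(C3CCCC3)CC(=O)N4C)cc2)CC1`: 10300 nM

Compound 3 gives the lowest of the two numbers; the step of a 2.5-fold lower number from compound 1 to compound 3 (0.40 log units; beyond the scatter) is the only measured one in the set, and it concerns methylation of the amide nitrogen of the shared core. For compound 2 only a limit is known (the limit of > 30000 nM in this assay, at which 1 of the 3 values shown sits).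

Compound 4 `CC1CCN(c2ccc(Nc3ncc4c(n3)N(C3CCCC3)CC(=O)N4C)cc2)CC1` carries 4-methylpiperidin-1-yl in place of 4-methylpiperazin-1-yl on an aromatic carbon. Among the compounds with values here, no measured step touches this part of the structure, so no direction can be taken from the series; the expectation is a change within the scatter, a 1.2-fold higher number from compound 3 to compound 4 (0.07 log units; within the scatter). Compound 4 is therefore estimated at 12000 nM in this assay, with a range from 4000 nM to 30000 nM.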

Compound 4, half-maximal inhibitory concentration: > 30000 nM
Compound 4: no number, only a limit; the forecaster's own chance of this, stated with the estimate: 25%; middle value at least 2.5-fold (0.39 log units) away from the limit.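

Within the data shown here, the position on the aromatic carbon is not neutral: 4-methylpiperidin-1-yl in place of 4-methylpiperazin-1-yl gives an at least 2.9-fold higher number from compound 3 to compound 4 (0.46 log units; beyond the scatter), the first measured step at this place. Compound 4 reads > 30000 nM, which is a limit and not a number, so the step has only a lower bound: the limit of > 30000 nM in this assay, at which 2 of the 4 values shown sit.

Open, going by these compounds, is how a morpholine ring, or a longer alkyl chain on the piperazine nitrogen, would read at this place. Also open, on these data alone, is whether any group here improves on compound 3 at 10300 nM.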